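Shortening the octyl chain on the cyclic phosphate core

The source may hold more compounds than are shown below. What is called first, only, known or untested is meant among the compounds shown, and "the series" means these compounds.

Compound 1 `CCCCCCCCc1cn([C@H]2C[C@@H]3OP(=O)(O)OC[C@H]3O2)c(=O)[nH]c1=O` is measured in a functional assay on Raji cells (Homo sapiens) (on this read-out higher numbers stand for weaker inhibition and lower numbers for stronger inhibition), at 184 ug/mL, the lowest of the two numbers shown. Compound 3 `CCCCCc1cn([C@H]2C[C@H](O)[C@@H](CO)O2)c(=O)[nH]c1=O`, which carries a pentyl chain on a different sugar, gives 328 ug/mL in this assay, within the scatter of compound 1. Compound 2 `CC(C)c1cn([C@H]2C[C@@H]3OP(=O)(O)OC[C@H]3O2)c(=O)[nH]c1=O` gives > 500 ug/mL, which is a limit and not a number: the limit of > 500 ug/mL in this assay, at which 1 of the 3 values shown sits. Among the compounds with values here, the step of an at least 2.7-fold higher number from compound 1 to compound 2 (0.43 log units; beyond the scatter) is the one comparison on the shared core, and it runs toward weaker inhibition on chain shortening. Compound 4 `CCCCc1cn([C@H]2C[C@@H]3OP(=O)(O)OC[C@H]3O2)c(=O)[nH]c1=O` differs from compound 1 by hydrogen in place of butyl on a saturated chain carbon, four bonds along the chain from an aromatic carbon. A modest rise in this assay is therefore expected, a 1.9-fold higher number from compound 1 to compound 4 (0.28 log units; within the scatter), smaller than the step to compound 2. Compound 4 is estimated at 350 ug/mL, with a range from 150 ug/mL to 800 ug/mL.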

Compound 4, concentration for 50% inhibition: 165 ug/mL
The estimate for compound 4 lay 2.1-fold (0.33 log units) above the measured number, and the stated range covers the measured number.
By their numbers in this assay, from the lowest: compounds 4, 1 and 3 (each within the scatter of the next). At a limit, above all of these: compound 2.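

Cutting octyl down to butyl on the shared core leaves this assay without a readable change (a 1.1-fold lower number from compound 1 to compound 4 (0.05 log units; within the scatter)), so the earlier drop cannot be read as simple chain shortening. Butyl and isopropyl do separate at this position (an at least 3.0-fold lower number from compound 2 to compound 4 (0.48 log units; beyond the scatter)). Compound 2 stands at a limit and not a number: the limit of > 500 ug/mL in this assay, at which 1 of the 4 values shown sits.

Going by these compounds, whether that separation follows chain length or branching stays open. Also open, on these data alone, is what a chain longer than octyl, or an amine or carboxylic acid at the chain end, would give on this core.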